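A few compounds are considered here, and "the series" means these few. Any claim that something is new, unique, unknown or untested is made for them only; others in the source may bear on it.

In a functional assay on DU-145 cells (Homo sapiens) for cytotoxicity, read by MTT assay (a lower number here means a stronger inhibitor, a higher number a weaker inhibitor), three compounds sharing one core have been measured. Compound 1 `CC(C)=CC[C@@H](OC[C@H](C)O)C1=CC(=O)c2c(O)ccc(O)c2C1=O` gives 24500 nM, and compound 3 `COCCO[C@H](CC=C(C)C)C1=CC(=O)c2c(O)ccc(O)c2C1=O` gives 43200 nM. These two numbers sit within the scatter of each other, as a 1.8-fold higher number from compound 1 to compound 3 (0.25 log units; within the scatter) shows, so neither can be ranked above the other. Compound 2 `CCCC(O)CC(=O)O[C@H](CC=C(C)C)C1=CC(=O)c2c(O)ccc(O)c2C1=O` gives only a limit of the assay, > 100000 nM.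

The next structure, compound 4 `CC(=O)OC(C)CO[C@H](CC=C(C)C)C1=CC(=O)c2c(O)ccc(O)c2C1=O`, differs from compound 3 in one place: 1-acetoxyethyl stands in place of methoxymethyl on a saturated chain carbon bound to an oxygen on a saturated carbon (1-acetoxyethyl in place of methoxymethyl on a saturated chain carbon bound to an oxygen on a saturated carbon). The most relevant evidence is the change at this same place, where 1-hydroxyethyl gave way to methoxymethyl, and that step, a 1.8-fold higher number from compound 1 to compound 3 (0.25 log units; within the scatter), stayed within the scatter. The larger steps, an at least 4.0-fold higher number from compound 1 to compound 2 (0.61 log units; beyond the scatter) and an at least 2.3-fold lower number from compound 2 to compound 3 (0.36 log units; beyond the scatter), involve a different place, the oxygen on a saturated carbon, so they bear on this change only weakly.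

Only a small change with no firm direction is therefore expected, and the estimated step, a 1.2-fold lower number from compound 3 to compound 4 (0.09 log units; within the scatter), lies within the scatter. For compound 4 the estimated value in this assay is 35000 nM, with an expected range from 12000 nM to 90000 nM.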

Compound 4, half-maximal inhibitory concentration: 16600 nM
For compound 4 the middle estimate is 2.1-fold (0.32 log units) above the measured one, and the stated range covers the measured number.
By their numbers in this assay, from the lowest: compounds 4, 1 and 3 (each within the scatter of the next, the first and the last beyond it). At a limit, above all of these: compound 2.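

At this place, on a saturated chain carbon bound to an oxygen on a saturated carbon, the earlier change stayed within the scatter, but in this assay 1-acetoxyethyl in place of methoxymethyl gives a step beyond it (a 2.6-fold lower number from compound 3 to compound 4 (0.42 log units; beyond the scatter)), so the numbers here do respond to what is attached. Yet 1-acetoxyethyl in place of 1-hydroxyethyl stays within the scatter (a 1.5-fold lower number from compound 1 to compound 4 (0.17 log units; within the scatter)), so capping that hydroxyl as an acetate leaves no readable difference, and only the methoxymethyl and 1-acetoxyethyl ends of this small series can be told apart. The step from the other side chain, 2-acetoxypropyl in place of (2-hydroxypentyl)carbonyl (an at least 6.0-fold lower number from compound 2 to compound 4 (0.77 log units; beyond the scatter)), shows that the acetoxy chain does not share that compound's result, but its size is only a bound since one end of it is a limit of the assay: (the limit of > 100000 nM in this assay, at which 1 of the 4 values shown sits).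

As far as these compounds go, whether an acyl group with a longer chain than acetyl, an amine or a carboxylic acid at this place would move the number further in either direction stays open. From the compounds shown here alone, the carbon carrying the acetoxy group in compound 4 is also drawn without a set configuration, so what its two mirror-image arrangements would each give remains unknown.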